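This account rests on a few compounds, and the source may have more. Where it says the series, first, only, none or still open, it means among the compounds named here.

Measured so far in a functional assay on the whole organism for inhibition, with Rattus norvegicus as the target, read by cytopathic effect and paw edema, at a dose of 100 mg/kg by the oral route; on this read-out lower numbers stand for less inhibition and higher numbers for more inhibition at the one dose given (going by the name of the read-out):
- compound 1 `O=C(Nc1ccc(Cl)cc1)c1c(O)c2cccnc2n(-c2ccccc2)c1=O` gives 2.5%
- compound 2 `O=C(Nc1ccc([N+](=O)[O-])cc1)c1c(O)c2cccnc2n(-c2ccccc2)c1=O` gives -25.8%
- compound 3 `O=C(Nc1ccncc1)c1c(O)c2cccnc2n(-c2ccccc2)c1=O` gives 24.3%

Compound 3 stands highest of the three in this assay, with both steps to it beyond the scatter: a number 21.8 percentage points higher from compound 1 to compound 3 (beyond the scatter) and a number 50.1 percentage points higher from compound 2 to compound 3 (beyond the scatter). The next compound, compound 4 `O=C(Nc1ccc(Cl)nc1)c1c(O)c2cccnc2n(-c2ccccc2)c1=O`, differs from compound 3 in one place: 6-chloropyridin-3-yl in place of pyridin-4-yl on an amide-type nitrogen. Among the compounds with values here, two measured steps bear on this. The step of a number 21.8 percentage points higher from compound 1 to compound 3 (beyond the scatter) is the closest: the chloro that was lost there returns with the 6-chloropyridin-3-yl group, while a ring nitrogen is kept, so that step is partly undone. The step of a number 28.3 percentage points lower from compound 1 to compound 2 (beyond the scatter) shows that exchanging nitro for chloro on an aromatic carbon shifted the read-out by a modest amount, so the chlorine itself is not neutral in this series. Within the data shown here, no measured pair contains a 6-chloropyridin-3-yl group, so the size is uncertain. A modest decrease is expected, a number 12.3 percentage points lower from compound 3 to compound 4 (beyond the scatter), one that may end within the scatter. For compound 4 the expected value is 12%, with a range from -10% to 30%.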

Compound 4, a percentage reported as inhibition, in the whole organism at one dose (the size of the read-out at that dose, not a potency): -4%
For compound 4 the middle estimate is 16 percentage points above the measured one; the measured number falls inside the stated range.
By their numbers in this assay, from the lowest: compound 2; then compounds 4 and 1 (each within the scatter of the next); then compound 3.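

In this assay, exchanging pyridin-4-yl for 6-chloropyridin-3-yl on the amide-type nitrogen does not hold the read-out, with a number 28.3 percentage points lower from compound 3 to compound 4 (beyond the scatter), so a pyridine ring alone does not secure the level of compound 3. Against the chlorinated phenyl amide the picture differs, with a number 6.5 percentage points lower from compound 1 to compound 4 (within the scatter), and against the nitro amide a number 21.8 percentage points higher from compound 2 to compound 4 (beyond the scatter), so the 6-chloropyridin-3-yl and 4-chlorophenyl groups cannot be told apart here, while the 4-nitrophenyl group stays clearly separate from both. No evidence on the cause of these steps is available.

The compounds shown do not separate the effect of the chloro from that of the place of the ring nitrogen, a question that a plain pyridin-3-yl group on the amide-type nitrogen would address. Also open, from the compounds shown here alone, is how an amine or a carboxylic acid in place of the chloro would read.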